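The compounds below may be only part of what the source reports. "The series", "measured", "known", "first", "only" and "open" are said of these compounds alone.

Working notes on the series in an ADME assay on microsomes from liver (Mus musculus) for metabolic stability; on this read-out higher numbers stand for a longer-lived compound and lower numbers for a shorter-lived compound. Compound 1 `N#Cc1cccc(N/C(=N\O)c2nonc2SCCNC(=O)CS(N)(=O)=O)c1` gives > 3 h, which is a limit of the assay and not a number. Among the compounds with values here, compound 2 `NS(=O)(=O)CC(=O)NCCSc1nonc1/C(=N/O)Nc1cccc(Br)c1` gives 0.918 h, the only actual number so far in this assay, so its standing rests on a single comparison.

The next compound is compound 3 `N#Cc1cc(N/C(=N\O)c2nonc2SCCNC(=O)CS(N)(=O)=O)ccc1F`. The change is 3-cyano-4-fluorophenyl in place of 3-bromophenyl on an amine nitrogen.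

Within the data shown here, one measured step bears on this change, an at least 3.2-fold lower number from compound 1 to compound 2 (0.51 log units; beyond the scatter). Read in reverse, that step points to a longer half-life when the cyano group returns in compound 3, though its size is known only as a bound. Among the measured compounds shown here, no measured step covers the fluorine in the entering group, which widens the uncertainty.

The expected change is upward and beyond the scatter, with an estimated 2.7-fold higher number from compound 2 to compound 3 (0.44 log units; beyond the scatter). For compound 3 the estimated half-life is 2.5 h, with an expected range of 1.1 h to 5.5 h.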

Compound 3, half-life: 2.38 h
Compound 3: middle estimate off by 1.1-fold (0.02 log units), on the high side; measured number inside the range.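

On the amine nitrogen, 3-cyano-4-fluorophenyl in place of 3-bromophenyl gives a step between two actual numbers in this assay: a 2.6-fold higher number from compound 2 to compound 3 (0.41 log units; beyond the scatter). The earlier step from bromo to cyano had only a bound for its size, whereas this comparison gives a measured size, running in the direction expected from that step read in reverse, although here the entering group also carries a fluorine. The step for fluoro in place of hydrogen on an aromatic carbon, an at least 1.2-fold lower number from compound 1 to compound 3 (0.10 log units; that floor lies within the scatter), cannot be read as a change, since its floor lies within the scatter and the value of compound 1 is a limit of the assay: the limit of > 3 h in this assay, at which 1 of the 3 values shown sits.

The step from bromo to the new group changes two substituents at once, so the shares of the nitrile and the fluorine in it remain unresolved, and a 3-bromo-4-fluorophenyl group would separate them. From the compounds shown here alone, it also remains open how the half-life would respond to an amine or a carboxylic acid on the phenyl ring, or to a longer chain on the sulfur of the shared core.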